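The compounds below may be only part of what the source reports. "The series", "measured", "known", "first", "only" and "open" are said of these compounds alone.

Measured in a functional assay on MCF7 cells (Homo sapiens) for inhibition, read by fluorescence, with a stated time of 72 h; a lower number here means a stronger inhibitor of growth, a higher number a weaker inhibitor of growth:
compound 1 `CCCCn1cnc2c(NCc3cccc(Cl)c3)nc(N[C@H]3CC[C@H](N)CC3)nc21` gives 2200 nM
compound 2 `COc1cc(Nc2nc(N[C@H]3CC[C@H](N)CC3)nc3c2ncn3CCC(C)C)cc(OC)c1` gives 4500 nM
compound 3 `CCCCCCn1cnc2c(Nc3cc(OC)cc(OC)c3)nc(N[C@H]3CC[C@H](N)CC3)nc21` gives 3500 nM

Compound 3 lies within the usual scatter of both other compounds, so these numbers set it clearly apart from neither. The next compound to be tested is compound 4 `CCCCn1cnc2c(Nc3cc(OC)cc(OC)c3)nc(N[C@H]3CC[C@H](N)CC3)nc21`. It differs from compound 3 in one place, with hydrogen in place of ethyl on a saturated chain carbon, four bonds along the chain from an aromatic nitrogen. The chain on that nitrogen is therefore shorter in compound 4.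

Within the data shown here, only one measured step changes this chain alone. That step is a 1.3-fold lower number from compound 2 to compound 3 (0.11 log units; within the scatter), with butyl in place of isopropyl on a saturated chain carbon, two bonds along the chain from an aromatic nitrogen. It stayed within the scatter, although it is a different change from the one here. Compound 1 carries the same chain as compound 4 but differs elsewhere on the shared core, so it offers only loose guidance.

On this evidence, no step beyond the scatter is expected in this assay. The estimated change is a 1.1-fold higher number from compound 3 to compound 4 (0.06 log units; within the scatter). For compound 4 the estimated value is 4000 nM, with an expected range from 2000 nM to 8000 nM.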

Compound 4, concentration for 50% growth inhibition: 4500 nM
Compound 4: middle estimate off by 1.1-fold (0.05 log units), on the low side; the measured number falls inside the stated range.
By their numbers in this assay, from the lowest: compounds 1, 3, 2 and 4 (each within the scatter of the next, the first and the last beyond it).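

In this assay, among these compounds, hydrogen in place of ethyl on a saturated chain carbon, four bonds along the chain from an aromatic nitrogen, gives a 1.3-fold higher number from compound 3 to compound 4 (0.11 log units; within the scatter) and so stays within the scatter, which is the first direct test of this shortening. Hydrogen in place of methyl on a saturated chain carbon bound to two saturated chain carbons gives no change at the digits printed from compound 2 to compound 4 (within the scatter) as well, so among compounds 2, 3 and 4, which share the 3,5-dimethoxyphenyl group, the three chains on that nitrogen are not told apart by this assay. Among the compounds shown here, the only step here beyond the scatter comes from the other end of the molecule, where 3,5-dimethoxyphenyl in place of 3-chlorobenzyl on a nitrogen on an aromatic ring gives a 2.0-fold higher number from compound 1 to compound 4 (0.31 log units; beyond the scatter) and marks that group as the place where a difference first appears, though a modest one.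

Still open, as far as these compounds go, is whether an amine or a carboxylic acid on the chain, or a much longer chain, would shift the number beyond the scatter. No measurement offered here explains any of these steps.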